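From Compound 2 to Compound 4: Amino in Place of Methoxy

A few compounds are considered here, and "the series" means these few. Any claim that something is new, unique, unknown or untested is made for them only; others in the source may bear on it.

The measured compounds and their values in a functional assay on B16 cells (Mus musculus) for cytotoxicity, read by MTT assay, with a stated time of 72 h; a lower number here means a stronger inhibitor, a higher number a weaker inhibitor:
Compound 1, `COc1ccc(/C=C/C(=O)Nc2cc(C(=O)c3cc(OC)c(OC)c(OC)c3)ccc2OC)cc1`, gives 8700 nM.
Compound 2, `COc1cccc(/C=C/C(=O)Nc2cc(C(=O)c3cc(OC)c(OC)c(OC)c3)ccc2OC)c1`, gives 3100 nM.
Compound 3, `COc1ccc(C(=O)c2cc(OC)c(OC)c(OC)c2)cc1NC(=O)/C=C/c1ccc(F)c(F)c1`, gives 6500 nM.

Compound 2 stands lowest of the three numbers in this assay; compound 3 is nearest to it and compound 1 furthest, both sitting at higher numbers beyond the scatter. The unmeasured compound 4, `COc1ccc(C(=O)c2cc(OC)c(OC)c(OC)c2)cc1NC(=O)/C=C/c1ccc(N)cc1`, differs from compound 2 in one place: 4-aminophenyl in place of 3-methoxyphenyl on a double-bonded chain carbon bound to a double-bonded chain carbon.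

Within the data shown here, two measured steps bear on this. The step of a 2.8-fold lower number from compound 1 to compound 2 (0.45 log units; beyond the scatter) shows that moving the methoxy from the 4-position to the 3-position of that phenyl ring lowered the number modestly, and the step of a 2.1-fold higher number from compound 2 to compound 3 (0.32 log units; beyond the scatter) shows that replacing the 3-methoxyphenyl with 3,4-difluorophenyl raised it modestly again. Among the measured compounds shown here, compound 4 returns to a ring substituted only in the 4-position, though with an amino group that brings one hydrogen-bond donor, which none of the measured rings carries. The closest guide remains compound 1, so a modest rise from compound 2 is expected, about a 1.9-fold higher number from compound 2 to compound 4 (0.29 log units; within the scatter), with the range kept wide. Compound 4 is therefore estimated at 6000 nM, between 2500 nM and 15000 nM.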

Compound 4, half-maximal inhibitory concentration: 7900 nM
The estimate for compound 4 lay 1.3-fold (0.12 log units) below the measured number, within the range that was stated.
By their numbers in this assay, from the lowest: compound 2; then compounds 3, 4 and 1 (each within the scatter of the next).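

In this assay there is a 2.5-fold higher number from compound 2 to compound 4 (0.41 log units; beyond the scatter) and this shows that the 4-aminophenyl group does not keep the lower number held by the 3-methoxyphenyl group. With a 1.1-fold lower number from compound 1 to compound 4 (0.04 log units; within the scatter) as the only difference, amino in place of methoxy on an aromatic carbon cannot be told apart from no change at all, so the hydrogen-bond donor that enters with the 4-aminophenyl group brings no readable difference on this ring. The third comparison, a 1.2-fold higher number from compound 3 to compound 4 (0.08 log units; within the scatter) in size, is also within the scatter, so among these four compounds only compound 2, with its 3-methoxyphenyl group, stands apart, while the 4-methoxyphenyl, 3,4-difluorophenyl and 4-aminophenyl rings cannot be separated from one another.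

No measurement at hand accounts for the separate standing of compound 2. On these data alone, it remains open whether a 3-aminophenyl ring would match the number of compound 2 and what a hydroxy or dimethylamino group would do on this ring.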